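Fluoro for Methylsulfanyl on a Fused Two-Ring Core

A few compounds are considered here, and "the series" means these few. Any claim that something is new, unique, unknown or untested is made for them only; others in the source may bear on it.

Compound 1 `CSc1cccc2c(=O)c(-c3nn[nH]n3)c[nH]c12`: 25 mg/kg
Compound 2 `COc1ccc(OC)c2c(=O)c(-c3nn[nH]n3)c[nH]c12`: > 10 mg/kg
Compound 3 `c1cc2ncc(-c3nn[nH]n3)cc2cc1OC1CCCCC1`: 10 mg/kg

In a functional assay on the whole organism (strain Sprague-Dawley) for inhibition, with Rattus norvegicus as the target (on this read-out lower numbers stand for an effect already at smaller amounts and higher numbers for an effect only at larger amounts of compound), compound 1 gives 25 mg/kg. For compound 2 the value > 10 mg/kg is a limit of the assay and not a number (the limit of > 10 mg/kg in this assay, at which 1 of the 3 values shown sits). Compound 3 gives 10 mg/kg. Of the two numbers, compound 1 has the higher one, so it acts only at a larger amount than compound 3, and that gap lies beyond the scatter.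

Compound 4 `O=c1c(-c2nn[nH]n2)c[nH]c2c(F)cccc12` differs from compound 1 in one place: fluoro in place of methylsulfanyl on an aromatic carbon. For the measured compounds named here, no measured pair shows this exchange, so the step from compound 1 to compound 4 is expected to be small, in either direction, and probably within the scatter no change at the digits printed from compound 1 to compound 4 (within the scatter). Compound 4 is therefore expected to give about 25 mg/kg, between 8 mg/kg and 80 mg/kg.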

Compound 4, minimum effective dose: 10 mg/kg
Beside the measured number, compound 4's estimate is 2.5-fold (0.40 log units) above it; measured number inside the range.
By their numbers in this assay, from the lowest: compounds 3 and 4 (each within the scatter of the next); then compound 1.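

Exchanging methylsulfanyl for fluoro on this aromatic carbon of the shared core gives a 2.5-fold lower number from compound 1 to compound 4 (0.40 log units; beyond the scatter) in this assay and thus shows that this position responds to a change of group. The methylsulfanyl group is not required for an effect in this whole-animal read-out, since the single fluorine atom keeps one at a smaller dose. Nothing given here accounts for the size or direction of this step.

On these data alone, how an amine or a longer chain such as butylsulfanyl would behave on this carbon remains open. As far as these compounds go, with a single pair, it also remains open whether the same exchange would give a similar step elsewhere on the core.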